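Acetyl for cyclopentenyl on the ether chain of compound 3

This account rests on a few compounds, and the source may have more. Where it says the series, first, only, none or still open, it means among the compounds named here.

Compound 3 `Nc1nc(OCC2=CCCC2)c2nc[nH]c2n1` gives the lowest number of the two numbers shown in an assay on HT-29 cells for inhibition of Methylated-DNA--protein-cysteine methyltransferase (Homo sapiens) (a lower number here means a stronger inhibitor, a higher number a weaker inhibitor), with 390 nM. Its nearest neighbour is compound 2 `CCCCOc1nc(N)nc2[nH]cnc12`, which in this assay gives 493000 nM. Compound 1 `CCOc1nc(N)nc2[nH]cnc12` sits at a limit of this assay and gives no number, only > 1000000 nM; see (the limit of > 1000000 nM in this assay, at which 1 of the 3 values shown sits).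

The measured steps show how much the group on the saturated chain carbon bound to the ring oxygen matters: a 1300-fold lower number from compound 2 to compound 3 (3.10 log units; beyond the scatter) and an at least 2500-fold lower number from compound 1 to compound 3 (3.40 log units; beyond the scatter), while an at least 2.0-fold lower number from compound 1 to compound 2 (0.30 log units; that floor lies within the scatter).

Compound 4 `CC(=O)COc1nc(N)nc2[nH]cnc12` is not yet measured. It differs from compound 3 as follows: acetyl in place of cyclopent-1-en-1-yl on a saturated chain carbon bound to an oxygen on an aromatic ring. The two large steps into compound 3 both bear on this change: they show that replacing a plain alkyl group at this position with cyclopent-1-en-1-yl lowers the number by a large margin, so taking the cyclopent-1-en-1-yl away again and putting in acetyl is expected to move the number back up, in the direction of compound 2 and compound 1, by a step of roughly that order. For compound 4 the expected step is a 260-fold higher number from compound 3 to compound 4 (2.41 log units; beyond the scatter). Compound 4 is therefore estimated at 100000 nM in this assay, within 10000 nM to 1000000 nM.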

Compound 4, half-maximal inhibitory concentration: 192000 nM
For compound 4 the middle estimate is 1.9-fold (0.28 log units) below the measured one; measured number inside the range.
By their numbers in this assay, from the lowest: compound 3; then compound 4; then compound 2. At a limit, above all of these: compound 1.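

The change shows that the strength of compound 3 in this assay does not survive the loss of cyclopent-1-en-1-yl when a different group with a double bond outside aromatic rings takes its place: a 490-fold higher number from compound 3 to compound 4 (2.69 log units; beyond the scatter). Set against the plain alkyl ethers, acetyl brings only a small change, with a 2.6-fold lower number from compound 2 to compound 4 (0.41 log units; beyond the scatter), so among the compounds shown the large drop in the number belongs to cyclopent-1-en-1-yl alone and not to every replacement of alkyl at this place. Compound 1 gives only a limit, so the change to acetyl there reads as an at least 5.2-fold lower number from compound 1 to compound 4 (0.71 log units; beyond the scatter), a floor and not a measured size: the limit of > 1000000 nM in this assay, at which 1 of the 4 values shown sits.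

The compounds shown leave open whether the ring, the double bond or the carbon count of cyclopent-1-en-1-yl carries the effect, a question that cyclopentyl or an open pentenyl chain on the same carbon would address. As far as these compounds go, it also remains open whether the small difference between acetyl and propyl rests on the carbonyl oxygen, which a 2-hydroxypropyl group or a carboxylic acid at this place would test.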